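Series notes: the step from compound 3 to compound 4

The compounds below may be only part of what the source reports. "The series", "measured", "known", "first", "only" and "open" are said of these compounds alone.

Measured so far:
compound 1 `Cn1cnc2nc(-c3ccc(Cl)cc3)nn2c1=S` gives 90% in a functional assay on the whole organism for inhibition, with Rattus norvegicus as the target, at a dose of 3 mg/kg by the intraperitoneal route; on this read-out lower numbers stand for less inhibition and higher numbers for more inhibition at the one dose given (going by the name of the read-out)
compound 2 `Cn1cnc2nc(-c3ccc(Br)cc3)nn2c1=S` gives 84% in this assay
compound 3 `Cc1nc2nc(-c3ccc(Cl)cc3)nn2c(=S)n1C` gives 60% in this assay

Compound 3 stands lowest of the three numbers in this assay; its nearest neighbour is compound 2, and the gap to compound 2 as well as the gap to compound 1 lies beyond the scatter. Two single-place steps are known: a number 6 percentage points lower from compound 1 to compound 2 (within the scatter) and a number 30 percentage points lower from compound 1 to compound 3 (beyond the scatter). Only the second bears on what follows, since it alone altered the aromatic carbon between two ring nitrogen atoms.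

Compound 4 `Cn1c(-c2ccccc2)nc2nc(-c3ccc(Cl)cc3)nn2c1=S` differs from compound 3 in one place: phenyl in place of methyl on an aromatic carbon. Among the compounds with values here, no measured pair shows a phenyl entering at this position, so the direction cannot be read from the data. Within the data shown here, the one step that touched this carbon, a number 30 percentage points lower from compound 1 to compound 3 (beyond the scatter), was a modest drop, and a change of comparable size in either direction is expected here, with the wide range reflecting that uncertainty. For compound 4 the estimate is 50% (range 20% to 80%), which amounts to an expected step of a number 10 percentage points lower from compound 3 to compound 4 (within the scatter).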

Compound 4, a percentage reported as inhibition, in the whole organism at one dose (the size of the read-out at that dose, not a potency): 5%
Compound 4: middle estimate off by 45 percentage points, on the high side; measured number outside the range, below it.
By their numbers in this assay, from the lowest: compound 4; then compound 3; then compounds 2 and 1 (each within the scatter of the next).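

At the aromatic carbon between two ring nitrogen atoms, the loss seen with methyl deepens sharply with phenyl in this assay, with a number 55 percentage points lower from compound 3 to compound 4 (beyond the scatter) and a number 85 percentage points lower from compound 1 to compound 4 (beyond the scatter). The three compounds that differ at this carbon now fall in one order, hydrogen, then methyl, then phenyl, and compound 4 at 5% retains very little inhibition at the one dose given, so this position is far from indifferent to what it carries. Nothing at hand explains this fall.

On these data alone, whether the fall follows the number of heavy atoms or the presence of the aromatic ring stays open, since only hydrogen, methyl and phenyl appear at this carbon. An amine, a carboxylic acid or a longer chain such as propyl at this position could help separate the two readings.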